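Swapping Hydroxymethyl for Amino: Expected Solubility Change

The source may report more compounds than this note shows. Statements on the series, on what has been measured and on what is new or still open speak of the compounds shown alone.

Measured so far:
Compound 1 `CC(C)n1nc(-c2ccc3oc(N)nc3c2)c2c(CO)nc(N)nc21` gives 82000 nM in a physicochemical assay for solubility, read by HPLC, in phosphate buffer, measured as kinetic solubility, with a stated time of 24 h, at 20 degrees C, at pH 7.4, tested at 100 uM; on this read-out higher numbers stand for higher solubility and lower numbers for lower solubility.
Compound 2 `CC(C)n1nc(-c2ccc3oc(N)nc3c2)c2c(C#N)nc(N)nc21` reaches only a limit in this assay, < 1000 nM.

Within the data shown here, compound 1 holds the only numerical solubility reading in this set; the one other value is a limit rather than a number. Among the measured compounds shown here, the single measured step, an at least 82-fold lower number from compound 1 to compound 2 (1.91 log units; beyond the scatter), replaces the hydroxymethyl with a nitrile and takes the reading down to the limit of < 1000 nM in this assay, at which 1 of the 2 values shown sits, so the real drop may be larger than the figure shows. Compound 3 `CC(C)n1nc(-c2ccc3oc(N)nc3c2)c2c(N)nc(N)nc21` changes the same position of compound 1 in a different way: amino in place of hydroxymethyl on an aromatic carbon. The incoming amino group keeps one hydrogen-bond donor and one acceptor, as the hydroxymethyl had, while the nitrile of compound 2 is a different group altogether. For the measured compounds named here, only one step exists to lean on, and it shows that altering this group can cost a great deal of solubility. A decrease smaller than that step is expected for compound 3, a 4.1-fold lower number from compound 1 to compound 3 (0.61 log units; beyond the scatter). Compound 3 is estimated at 20000 nM, with a likely range from 3000 nM to 80000 nM.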

Compound 3, solubility: 88000 nM
The estimate for compound 3 lay 4.4-fold (0.64 log units) below the measured number; the whole stated range lies below it.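

In this assay, amino in place of hydroxymethyl on an aromatic carbon gives a 1.1-fold higher number from compound 1 to compound 3 (0.03 log units; within the scatter), so the two groups cannot be told apart at this position on this read-out. The same position also gives an at least 88-fold higher number from compound 2 to compound 3 (1.94 log units; beyond the scatter), which shows that a change here need not end at a low reading, as the nitrile of compound 2 did, and that among the three compounds shown, compound 2 is the one that stands apart. That step is only a minimum, since compound 2 has a limit rather than a number: the limit of < 1000 nM in this assay, at which 1 of the 3 values shown sits.

The hydroxymethyl and the amino match in their hydrogen-bond donor and acceptor counts, but three compounds cannot tell whether that match has anything to do with their matching readings. Going by these compounds, how a methyl group or a carboxylic acid would read at this place stays open, as does whether the same swaps would give the same picture on a core other than the one shared here.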